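From Butyl to 3-Hydroxypropyl on the Shared Core

The source may hold more compounds than are shown below. What is called first, only, known or untested is meant among the compounds shown, and "the series" means these compounds.

In an ADME assay on HEK293 cells (Homo sapiens) for cytotoxicity, read by MTT assay, with a stated time of 48 h (on this read-out lower numbers stand for stronger inhibition and higher numbers for weaker inhibition), compound 1 `CCN(CC)CCn1c(N)c(-c2nc3ccccc3[nH]2)c2nc(C#N)c(C#N)nc21` gives 12200 nM and compound 2 `CCN(CC)CCCn1c(N)c(-c2nc3ccccc3[nH]2)c2nc(C#N)c(C#N)nc21` gives 7870 nM, and the step between them lies within the scatter: a 1.6-fold lower number from compound 1 to compound 2 (0.19 log units; within the scatter). Compound 3 `CCCCn1c(N)c(-c2nc3ccccc3[nH]2)c2nc(C#N)c(C#N)nc21` gives > 50000 nM, which is a limit of the assay and not a number (the limit of > 50000 nM in this assay, at which 1 of the 3 values shown sits). Going by these compounds, it therefore stands at the high end of the values shown, and its true value remains unknown.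

Compound 4 `N#Cc1nc2c(-c3nc4ccccc4[nH]3)c(N)n(CCCO)c2nc1C#N` has hydroxy in place of methyl on a saturated chain carbon, three bonds along the chain from an aromatic nitrogen. The same difference reads as butyl to 3-hydroxypropyl.

Among the compounds with values here, no measured step swaps in hydroxy, so the evidence is indirect. Within the data shown here, two steps bear on the change, both at this chain and both removing diethylamino: an at least 6.3-fold higher number from compound 2 to compound 3 (0.80 log units; beyond the scatter) and an at least 4.0-fold higher number from compound 1 to compound 3 (0.61 log units; beyond the scatter). Both lie beyond the scatter. Compound 4 carries no diethylamino either, so it is expected to stay with compound 3 rather than move towards compound 1 or compound 2. The expected outcome in this assay is an at least 1.2-fold lower number from compound 3 to compound 4 (0.09 log units; that floor lies within the scatter), which amounts to no clear change in either direction. For compound 4 the estimated value is 40000 nM, with an expected range from 15000 nM to 90000 nM.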

Compound 4, half-maximal inhibitory concentration: > 50000 nM
Compound 4 ended at the assay's limit (the forecaster's own chance of this, stated with the estimate: 55%); at least 1.2-fold (0.09 log units) between middle value and limit.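

Compound 3 and compound 4 both sit at a limit in this assay, so the step between them cannot be read, and the effect of hydroxy in place of methyl at this position stays unresolved: the limit of > 50000 nM in this assay, at which 2 of the 4 values shown sit.

What compound 4 adds is a second chain without diethylamino that reaches this limit, with hydroxy in place of diethylamino giving an at least 6.3-fold higher number from compound 2 to compound 4 (0.80 log units; beyond the scatter) and hydroxymethyl in place of diethylamino giving an at least 4.0-fold higher number from compound 1 to compound 4 (0.61 log units; beyond the scatter) and both steps lying beyond the scatter. Among the four compounds, the two carrying diethylamino give numbers and the two without it sit at the limit, and no compound goes against this pattern.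

Going by these compounds, how far compound 3 and compound 4 lie past the limit remains open, and so does any difference between them. On these data alone, it is also open whether diethylamino itself matters or whether another amine at the end of the chain, such as a primary amine or morpholine, would give a number in the same range, and how a carboxylic acid there would read.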